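Ethoxy to methoxy: working notes on compound 3

The compounds below may be only part of what the source reports. "The series", "measured", "known", "first", "only" and "open" are said of these compounds alone.

Within the data shown here, in a functional assay on MCF7 cells (Homo sapiens) for cytotoxicity (on this read-out lower numbers stand for stronger inhibition and higher numbers for weaker inhibition), compound 2 (`CCOc1ccc2nc(NC(=O)CCCCCCC(=O)NO)sc2c1`) gives 11.6 ug/mL and compound 1 (`CS(=O)(=O)c1ccc2nc(NC(=O)CCCCCCC(=O)NO)sc2c1`) gives 15.4 ug/mL as the only two numbers so far, within the scatter of each other. Compound 3 (`COc1ccc2nc(NC(=O)CCCCCCC(=O)NO)sc2c1`) differs from compound 2 by hydrogen in place of methyl on a saturated chain carbon bound to an oxygen on an aromatic ring, so ethoxy becomes methoxy. Among the measured compounds shown here, the one measured step, a 1.3-fold lower number from compound 1 to compound 2 (0.12 log units; within the scatter) for ethoxy in place of methylsulfonyl, stays within the scatter and is the only evidence at hand. No shift beyond the scatter is therefore expected, and the estimated step is a 1.0-fold higher number from compound 2 to compound 3 (0.01 log units; within the scatter) in this assay on this small change. For compound 3 the expected value is 12 ug/mL with an estimated range of 6 ug/mL to 24 ug/mL in this read-out.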

Compound 3, half-maximal inhibitory concentration: 1.85 ug/mL
Beside the measured number, compound 3's estimate is 6.5-fold (0.81 log units) above it, and the stated range ends above it.
By their numbers in this assay, from the lowest: compound 3; then compounds 2 and 1 (each within the scatter of the next).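

In this assay, among these compounds, the ethoxy group is not interchangeable with methoxy: removing the terminal methyl gives a 6.3-fold lower number from compound 2 to compound 3 (0.80 log units; beyond the scatter) and is the first step beyond the scatter. Methoxy also separates from methylsulfonyl on the same aromatic carbon, with an 8.3-fold lower number from compound 1 to compound 3 (0.92 log units; beyond the scatter) even though ethoxy and methylsulfonyl stayed within the scatter of each other. No data at hand account for this difference between methoxy and ethoxy.

Going by these compounds, whether hydroxy or a longer chain such as propoxy would extend or reverse this step remains open. On these data alone, whether the step carries over to any other read-out also remains open.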